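The source may hold more compounds than are shown below. What is called first, only, known or untested is meant among the compounds shown, and "the series" means these compounds.

Within the data shown here, compound 2 `CN1CCN(c2nc(-c3cccc(Cl)c3)nc3[nH]cnc23)CC1` gives 100 nM in an assay on cells for displacement of a labelled ligand from adenosine receptor A3 (Homo sapiens), read by scintillation counting and radioligand binding, with a stated time of 180 min (on this read-out lower numbers stand for stronger inhibition and higher numbers for weaker inhibition), the highest of the two numbers measured so far; compound 1 `CN1CCN(c2nc(-c3ccc(Cl)c(Cl)c3)nc3[nH]cnc23)CC1` gives 39.8 nM. Compound 3 `CN1CCN(c2nc(-c3cc(Cl)ccc3Cl)nc3[nH]cnc23)CC1` carries chloro in place of hydrogen on an aromatic carbon, which reads 3-chlorophenyl to 2,5-dichlorophenyl. Among the measured compounds shown here, the one step that bears on this, a 2.5-fold higher number from compound 1 to compound 2 (0.40 log units; beyond the scatter), shows a chloro added on the same ring at a different place lowering the number modestly. For the measured compounds named here, a chloro ortho to a large group has no precedent here, so compound 3 is expected to stay near compound 2, estimated at 120 nM with a range of 30 nM to 500 nM, an expected step of a 1.2-fold higher number from compound 2 to compound 3 (0.08 log units; within the scatter).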

Compound 3, inhibition constant: 251 nM
Compound 3: the middle estimate sits 2.1-fold (0.32 log units) below what was measured; low and high end bracket the measured number.
By their numbers in this assay, from the lowest: compound 1; then compound 2; then compound 3.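

Adding a chloro ortho to a large group moves the number up, with a 2.5-fold higher number from compound 2 to compound 3 (0.40 log units; beyond the scatter) in this series, so a second chloro on the 3-chlorophenyl does not help at every place. Where the two chloro groups sit matters: a 6.3-fold higher number from compound 1 to compound 3 (0.80 log units; beyond the scatter) separates 2,5-dichlorophenyl from 3,4-dichlorophenyl. Nothing available gives a reason for this difference. The compounds shown leave open whether a fluoro, a methyl or a methoxy ortho to a large group would give a similar step, and whether that step depends on the chloro para to it.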